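From methanesulfonamido to (cyclopropylcarbamoyl)amino on a shared core

The source may report more compounds than this note shows. Statements on the series, on what has been measured and on what is new or still open speak of the compounds shown alone.

Values measured in a functional assay on DU-145 cells (Homo sapiens) for antiproliferative activity, read by MTT assay, with a stated time of 3 days (on this read-out lower numbers stand for stronger inhibition and higher numbers for weaker inhibition), are these:
- compound 1 (`COc1cc(O)c2c(=O)cc(-c3ccc(NS(C)(=O)=O)cc3)oc2c1OC(C)C`) gives 19100 nM
- compound 2 (`CCS(=O)(=O)Nc1ccc(-c2cc(=O)c3c(O)cc(OC)c(OC(C)C)c3o2)cc1`) gives 17000 nM
- compound 3 (`C=CC(=O)Nc1ccc(-c2cc(=O)c3c(O)cc(OC)c(OC(C)C)c3o2)cc1`) gives 14700 nM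

Compound 1 stands level with the other two, since all three values lie within the usual scatter of one another. Compound 4 (`COc1cc(O)c2c(=O)cc(-c3ccc(NC(=O)NC4CC4)cc3)oc2c1OC(C)C`) keeps the core of compound 1 and changes one group (cyclopropylcarbamoyl in place of methylsulfonyl on a nitrogen on an aromatic ring). Here cyclopropylcarbamoyl replaces methylsulfonyl on a nitrogen on an aromatic ring. Two measured steps change the group on that nitrogen, a 1.3-fold lower number from compound 1 to compound 3 (0.11 log units; within the scatter) and a 1.2-fold lower number from compound 2 to compound 3 (0.06 log units; within the scatter), and both stay within the scatter. So does a 1.1-fold lower number from compound 1 to compound 2 (0.05 log units; within the scatter) on the sulfonyl chain. Within the data shown here, no measured compound carries cyclopropylcarbamoyl, so this evidence is indirect. No step beyond the scatter is therefore expected in this assay, and the estimated step is a 1.3-fold lower number from compound 1 to compound 4 (0.10 log units; within the scatter) at most in size terms of the scatter. Compound 4 is expected at 15000 nM with 7000 nM to 30000 nM as its estimated range.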

Compound 4, half-maximal inhibitory concentration: 15600 nM
The estimate for compound 4 lay 1.0-fold (0.02 log units) below the measured number; the measured number falls inside the stated range.
By their numbers in this assay, from the lowest: compounds 3, 4, 2 and 1 (each within the scatter of the next).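

Cyclopropylcarbamoyl on a nitrogen on an aromatic ring, with its three-membered ring and hydrogen-bond donor, stands level with the sulfonyl and vinylcarbonyl groups in this assay: there is a 1.2-fold lower number from compound 1 to compound 4 (0.09 log units; within the scatter) and a 1.1-fold lower number from compound 2 to compound 4 (0.04 log units; within the scatter) and also a 1.1-fold higher number from compound 3 to compound 4 (0.03 log units; within the scatter). This place on the shared core has now taken a group with a ring and still given no step beyond the scatter. No measured evidence bears on this result.

The compounds shown leave open whether any group at this place can give a step beyond the scatter. A free amine or a carboxylic acid on this ring could test that.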